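Adding a Hydroxy to the Ethoxy Chain of Compound 2

The compounds below may be only part of what the source reports. "The series", "measured", "known", "first", "only" and "open" are said of these compounds alone.

Among the compounds with values here, compound 2 `CCOc1cc(-c2cc3c(O)nc(C)nc3cc2C(C)C)ccc1Cl` stands lowest of the two numbers measured so far: in a functional assay for inhibition of transient receptor potential cation channel subfamily V member 1 (Homo sapiens), read by fluorescence and calcium flux (a lower number here means a stronger inhibitor, a higher number a weaker inhibitor), compound 2 gives 12 nM. The other compound, compound 1 `CC(C)c1cc2nc(N)nc(O)c2cc1-c1ccc(Cl)cc1`, gives 133 nM in this assay, a gap beyond the scatter. Compound 1 and compound 2 differ in more than one place, so no single change is read from them. Compound 3 `Cc1nc(O)c2cc(-c3ccc(Cl)c(OCCO)c3)c(C(C)C)cc2n1` differs from compound 2 in one place: hydroxy in place of hydrogen on a saturated chain carbon, two bonds along the chain from an oxygen on an aromatic ring. Within the data shown here, no step of this kind has been measured here, so only a small shift is expected, about a 1.7-fold higher number from compound 2 to compound 3 (0.22 log units; within the scatter). Compound 3 is estimated at 20 nM, between 6 nM and 70 nM.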

Compound 3, half-maximal inhibitory concentration: 557 nM
For compound 3 the middle estimate is 28-fold (1.44 log units) below the measured one; measured number above the stated range.
By their numbers in this assay, from the lowest: compound 2; then compound 1; then compound 3.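

In this assay, changing ethoxy to 2-hydroxyethoxy gives a 46-fold higher number from compound 2 to compound 3 (1.67 log units; beyond the scatter), a large loss of inhibition. This shows that the chain is not indifferent to change here: one hydroxy in place of a hydrogen on this saturated chain carbon is enough to weaken the compound sharply. Nothing available here accounts for the loss.

Still open, going by these compounds, is whether a methoxy or an amine on the same chain carbon would cost as much as the hydroxy. It is also unknown whether a longer chain carrying a hydroxy would behave the same way.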